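Nitro removal on the enone arm of the shared core

A few compounds are considered here, and "the series" means these few. Any claim that something is new, unique, unknown or untested is made for them only; others in the source may bear on it.

Compound 1 `CC1(C)S[C@@H]2/C(=C\C(=O)c3ccc([N+](=O)[O-])cc3)C(=O)N2[C@H]1C(=O)OC(c1ccccc1)c1ccccc1` is measured in a functional assay on A-375 cells (Homo sapiens) for cytotoxicity, read by MTT assay, with a stated time of 48 h (on this read-out higher numbers stand for weaker inhibition and lower numbers for stronger inhibition), and gives 50300 nM. Among the measured compounds shown here, this is the only number so far. Compound 2 `COC(=O)/C=C1\C[C@H]2SC(C)(C)[C@H](C(=O)OC(c3ccccc3)c3ccccc3)N2C1=O` gives > 100000 nM in this assay, a limit rather than a number, marking (the limit of > 100000 nM in this assay, at which 1 of the 2 values shown sits). Compound 1 therefore stands as the single quantified point, with compound 2 beyond the measurable range.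

Compound 3 `CC1(C)S[C@@H]2/C(=C\C(=O)c3ccccc3)C(=O)N2[C@H]1C(=O)OC(c1ccccc1)c1ccccc1` is not yet measured. The change from compound 1 to compound 3 reads (hydrogen in place of nitro on an aromatic carbon), hydrogen in place of nitro on an aromatic carbon, the 4-nitrophenyl becoming phenyl. For the measured compounds named here, no measured step of this kind exists, so the direction cannot be drawn from data. Compound 3 is expected to sit close to compound 1, with a step of a 1.2-fold higher number from compound 1 to compound 3 (0.08 log units; within the scatter) that stays within the usual scatter. Compound 3 is therefore estimated at 60000 nM, with a range from 20000 nM to 100000 nM, and with a real chance that only a limit is reported.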

Compound 3, half-maximal inhibitory concentration: 22800 nM
For compound 3 the middle estimate is 2.6-fold (0.42 log units) above the measured one; the measured number falls inside the stated range.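

Hydrogen in place of nitro on the aromatic carbon, para to a large group, is the first change in the series that can be read as a step: in this assay it appears as a 2.2-fold lower number from compound 1 to compound 3 (0.34 log units; beyond the scatter) and lies beyond the usual scatter. The 4-nitrophenyl is therefore not required for a measurable number on this read-out, since the plain phenyl of compound 3 also gives one, and on this single pair the nitro group brings no gain. Nothing available accounts for the size or direction of this step.

As far as these compounds go, with only nitro and hydrogen at this position, the shape of any trend there remains open. An amine, a methoxy group or a carboxylic acid on the same aromatic carbon could show whether the step extends to other groups.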